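Pyridin-3-yl in Place of Phenyl: What to Expect

The source may hold more compounds than are shown below. What is called first, only, known or untested is meant among the compounds shown, and "the series" means these compounds.

Measured so far in an assay on Sf9 cells for inhibition of protein deacetylase HDAC6 (Homo sapiens), read by fluorescence, with a stated time of 90 min; on this read-out higher numbers stand for weaker inhibition and lower numbers for stronger inhibition:
compound 1 `O=C(NO)c1ccc(Cn2c(=O)c(O)c(-c3ccccc3)c3ccccc32)cc1` gives 308 nM;
compound 2 `COc1c(-c2ccccc2)c2ccccc2n(Cc2ccc(C(=O)NO)cc2)c1=O` gives 61.6 nM;
compound 3 `O=C(NO)c1ccc(Cn2c(=O)c(OCc3ccccc3)c(-c3ccccc3)c3ccccc32)cc1` gives 84.5 nM.

Compound 1 has the highest number of the three and is thus the weakest inhibitor among them. Its steps to the others are a 5.0-fold lower number from compound 1 to compound 2 (0.70 log units; beyond the scatter) and a 3.6-fold lower number from compound 1 to compound 3 (0.56 log units; beyond the scatter), both beyond the scatter, while the remaining step is a 1.4-fold higher number from compound 2 to compound 3 (0.14 log units; within the scatter). Compound 4 `O=C(NO)c1ccc(Cn2c(=O)c(O)c(-c3cccnc3)c3ccccc32)cc1` differs from compound 1 in a single place: pyridin-3-yl in place of phenyl on an aromatic carbon. Going by the values given here, none of the measured steps touches that place; all of them concern what sits on the hydroxy oxygen. The data therefore give no guide for this change, and the expected step is a 1.0-fold lower number from compound 1 to compound 4 (0.01 log units; within the scatter), not beyond the scatter in either direction. Compound 4 is accordingly estimated at 300 nM, with a range from 100 nM to 900 nM.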

Compound 4, half-maximal inhibitory concentration: 296 nM
Compound 4: the middle estimate sits 1.0-fold (0.01 log units) above what was measured; measured number inside the range.
By their numbers in this assay, from the lowest: compounds 2 and 3 (each within the scatter of the next); then compounds 4 and 1 (each within the scatter of the next).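

In this assay, pyridin-3-yl in place of phenyl on this aromatic carbon gives a 1.0-fold lower number from compound 1 to compound 4 (0.02 log units; within the scatter). Going by these compounds alone, this is the first reading at this position, and a ring nitrogen, counted as a hydrogen-bond acceptor, enters here with no change beyond the scatter. No measured information explains this result.

Still open, going by these compounds, is how other groups at this carbon would read, such as pyridin-4-yl or a phenyl carrying an amine or a carboxylic acid. Also open, on these data alone, is whether pyridin-3-yl gives the same result with the methyl of compound 2 or the benzyl of compound 3 on the oxygen.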